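Removing the Methyl Branch: Compound 3 to Compound 4

The source may hold more compounds than are shown below. What is called first, only, known or untested is meant among the compounds shown, and "the series" means these compounds.

Measured compounds:
compound 1 `C[C@H](Nc1cc(F)c(S(=O)(=O)Nc2cscn2)cc1Cl)c1ccccc1` — 650 nM
compound 2 `C[C@H](Nc1cc(F)c(S(=O)(=O)Nc2cscn2)cc1Cl)c1ccccc1F` — 410 nM
compound 3 `C[C@H](Nc1cc(F)c(S(=O)(=O)Nc2cscn2)cc1Cl)c1cc(F)ccc1F` — 119 nM

The three measured compounds share one core and differ only in the fluorine count on the phenyl ring attached to the saturated chain carbon. In an assay on HEK293 cells for inhibition of SCN8A/SCN1B (Homo sapiens), read by patch clamp, with a stated time of 20 min (on this read-out higher numbers stand for weaker inhibition and lower numbers for stronger inhibition), compound 1 gives 650 nM, compound 2 gives 410 nM and compound 3 gives 119 nM. The step of a 1.6-fold lower number from compound 1 to compound 2 (0.20 log units; within the scatter) stays within the scatter, while a 5.5-fold lower number from compound 1 to compound 3 (0.74 log units; beyond the scatter) and a 3.4-fold lower number from compound 2 to compound 3 (0.54 log units; beyond the scatter) both go beyond it. Compound 3 therefore stands lowest of the three numbers in this assay, beyond the scatter from both of the others.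

Compound 4 `O=S(=O)(Nc1cscn1)c1cc(Cl)c(NCc2cc(F)ccc2F)cc1F` keeps the difluorophenyl ring of compound 3 but changes the chain: hydrogen in place of methyl on a saturated chain carbon bound to an aromatic carbon and a nitrogen on an aromatic ring. For the measured compounds named here, none of the measured steps touches this chain carbon; all three concern fluorine on the aromatic ring, so no measured step bears directly on the change from compound 3 to compound 4. With no guiding comparison, the expectation for this assay is a number near that of compound 3, with wide uncertainty in both directions, and a step of a 2.5-fold higher number from compound 3 to compound 4 (0.40 log units; beyond the scatter) is estimated. Compound 4 is thus expected to give 300 nM, with a plausible range from 100 nM to 1000 nM.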

Compound 4, half-maximal inhibitory concentration: 450 nM
Beside the measured number, compound 4's estimate is 1.5-fold (0.18 log units) below it; the measured number falls inside the stated range.
By their numbers in this assay, from the lowest: compound 3; then compounds 2, 4 and 1 (each within the scatter of the next).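

In this assay, for the compounds shown here, the methyl on this saturated chain carbon turns out to matter: hydrogen in its place gives a 3.8-fold higher number from compound 3 to compound 4 (0.58 log units; beyond the scatter) and this is the first measured change away from the ring fluorines that moves the number beyond the scatter. The comparisons with the compounds that keep the methyl show how much of the earlier difference is lost, with a 1.1-fold higher number from compound 2 to compound 4 (0.04 log units; within the scatter) and a 1.4-fold lower number from compound 1 to compound 4 (0.16 log units; within the scatter) both staying within the scatter. So the 2,5-difluorobenzyl group of compound 4 reads the same in this assay as the 1-(2-fluorophenyl)ethyl group of compound 2 and the 1-phenylethyl group of compound 1, and the difference between compound 1 and compound 3 does not survive without the methyl.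

The compounds shown leave open what a larger or different group on this chain carbon would do, such as an ethyl, a hydroxymethyl or a cyclopropyl group, and whether any of them would give a lower number than the methyl of compound 3. No further measurement bearing on this result is available, and the reason for the step stays open.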